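The source may report more compounds than this note shows. Statements on the series, on what has been measured and on what is new or still open speak of the compounds shown alone.

Compound 1 `CC(CCO)n1cnc2c(Cl)ncnc21`: > 50000 nM
Compound 2 `CCCCC(CCO)n1cnc2c(Cl)ncnc21`: > 50000 nM

Both entries come from a functional assay on SW480 cells (Homo sapiens) for antiproliferative activity, read by MTT assay, with a stated time of 48 h (on this read-out higher numbers stand for weaker inhibition and lower numbers for stronger inhibition), and both are limits of the assay, not measured numbers. Compound 2 therefore has no exact position, only its limit of > 50000 nM. For the measured compounds named here, the one other value shown is also a limit, so the whole set so far rests at the limit of > 50000 nM in this assay, at which 2 of the 2 values shown sit.

The next compound is compound 3 `CCCCCC(CCO)n1cnc2c(Cl)ncnc21`. It differs from compound 2 by methyl in place of hydrogen on a saturated chain carbon, five bonds along the chain from an aromatic nitrogen. In words, this is methyl in place of hydrogen on a saturated chain carbon, five bonds along the chain from an aromatic nitrogen, which can also be read as propyl to butyl.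

Going by the values given here, only one measured step bears on this change: a step that the two limits leave unreadable from compound 1 to compound 2. That step also added to the chain, but it offers neither a size nor a direction to carry forward. No shift beyond the usual scatter is therefore expected, and compound 3 may well be reported only as a limit. The expected change is a number no higher from compound 2 to compound 3 (the limit leaves the size open). For compound 3 the estimated value is 50000 nM, with an expected range of 25000 nM to 100000 nM.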

Compound 3, half-maximal inhibitory concentration: > 50000 nM
Compound 3 ended at the assay's limit; the forecaster's own chance of this, stated with the estimate: 70%; the middle value sits exactly at the limit.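

Compound 3, like compound 1 and compound 2, is reported only as a limit of the assay and not as a number, so neither step to compound 3 can be read. The compounds shown leave open how strongly each one acts and whether chain length changes that at all, since all of them rest at one point: the limit of > 50000 nM in this assay, at which 3 of the 3 values shown sit.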